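This account rests on a few compounds, and the source may have more. Where it says the series, first, only, none or still open, it means among the compounds named here.

Notes on the series in an assay on HEK293 cells for displacement of a labelled ligand from Melanocortin receptor 4 (Homo sapiens); a higher number here means a weaker inhibitor, a lower number a stronger inhibitor.

Compound 1 `CC(C)C[C@H](N)c1cc(C(F)(F)F)ccc1N1CCN(C(=O)[C@H]2CS(=O)(=O)C[C@@H]2c2ccc(Cl)cc2)CC1` carries a free amine on the side chain; in this assay compound 1 gives 38 nM. Compound 2 `CN[C@H](C)C(=O)N[C@@H](CC(C)C)c1cc(C(F)(F)F)ccc1N1CCN(C(=O)[C@H]2CS(=O)(=O)C[C@@H]2c2ccc(Cl)cc2)CC1` replaces the amine hydrogen with a (1-(methylamino)ethyl)carbonyl group, and in this assay compound 2 gives 100 nM. Going by the values given here, the move is a 2.6-fold higher number from compound 1 to compound 2 (0.42 log units; beyond the scatter), so compound 2 stands as the highest of the two numbers measured so far, with compound 1 as its nearest and only neighbour.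

Compound 3 `CNCC(=O)N[C@@H](CC(C)C)c1cc(C(F)(F)F)ccc1N1CCN(C(=O)[C@H]2CS(=O)(=O)C[C@@H]2c2ccc(Cl)cc2)CC1` is the next step from compound 2. The change is hydrogen in place of methyl on a saturated chain carbon bound to an amine nitrogen and a carbonyl carbon, so that the 1-(methylamino)ethyl group of compound 2 becomes a (methylamino)methyl group. Among the compounds with values here, no measured step covers this kind of edit; the only measured step concerns the addition of the whole acyl group rather than a change within it, and it is modest. Nothing in the shown numbers therefore points to a step beyond the scatter in either direction in this assay, and the estimate for compound 3 is no change at the digits printed from compound 2 to compound 3 (within the scatter), giving an expected value of 100 nM, with a likely range from 40 nM to 250 nM.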

Compound 3, inhibition constant: 180 nM
The estimate for compound 3 lay 1.8-fold (0.26 log units) below the measured number; the range from low to high includes it.
By their numbers in this assay, from the lowest: compound 1; then compounds 2 and 3 (each within the scatter of the next).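

Within (this assay), the methyl on the saturated chain carbon bound to an amine nitrogen and a carbonyl carbon is the first place in the series where an edit inside the acyl group can be read, and exchanging it for hydrogen stays within the scatter (a 1.8-fold higher number from compound 2 to compound 3 (0.26 log units; within the scatter)), so this methyl makes no readable difference between this pair. The acyl step now has a second example: the ((methylamino)methyl)carbonyl group in place of hydrogen on the amine nitrogen gives a step beyond the scatter (a 4.7-fold higher number from compound 1 to compound 3 (0.68 log units; beyond the scatter)), in the same direction as the step to the (1-(methylamino)ethyl)carbonyl group, so both acylated compounds give higher numbers than the free amine. That free amine is compound 1 (38 nM). Nothing available accounts for either step.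

The compounds shown leave open whether a larger group on that chain carbon, such as an ethyl or isopropyl, or the opposite configuration at that carbon would move the number beyond the scatter. Also open, from the compounds shown here alone, is whether an acyl group ending in a dimethylamino group, a hydroxyl or a carboxylic acid, rather than a methylamino group, would come back to the level of compound 1.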